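Cytotoxicity notes on a four-compound series at the limit

A few compounds are considered here, and "the series" means these few. Any claim that something is new, unique, unknown or untested is made for them only; others in the source may bear on it.

Compound 1 `Clc1ccc(NCc2cncn2Cc2ccc(-c3ccccc3)cc2)cc1-c1ccccc1`: in a toxicity assay on NIH3T3 cells (Mus musculus) for cytotoxicity, read by resazurin assay (on this read-out higher numbers stand for an effect only at larger amounts of compound and lower numbers for an effect already at smaller amounts), compound 1 gives > 1000 nM, a limit of the assay.
Compound 2 `Nc1cc(-c2ccccc2)ccc1Cn1cncc1CNc1ccc(Cl)c(-c2ccccc2)c1`: in this assay compound 2 gives > 1000 nM, again a limit.
Compound 3 `Cc1cccc(-c2cc(NCc3cncn3Cc3ccc(-c4ccccc4)cc3)ccc2-c2nc3ccccc3s2)c1C`: in this assay compound 3 gives > 1000 nM, again a limit.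

Compound 1 therefore stands nowhere on a numerical scale in this assay; it is known only by its limit, and the two further values shown are limits as well. For the measured compounds named here, the one step between measured compounds, a step that the two limits leave unreadable from compound 1 to compound 2, cannot be read for size or direction. The whole of the evidence is the limit of > 1000 nM in this assay, at which 3 of the 3 values shown sit, which rules out reading any step from these data.

Compound 4 `c1ccc(-c2ccc(Cn3cncc3CNc3ccc(-c4onc5ccccc45)c(-c4ccccc4)c3)cc2)cc1` is not yet measured. It differs from compound 1 by a group of 9 heavy atoms (7 carbon, 1 nitrogen, 1 oxygen; one five-membered aromatic ring with 2 hetero atoms, one six-membered aromatic ring of carbon only) in place of one chlorine atom, on an aromatic carbon. Going by the values given here, no measured step bears on this change; the only comparison available, a step that the two limits leave unreadable from compound 1 to compound 2, is itself unreadable. Compound 3, which carries a larger group than compound 1 while sitting at the same limit, suggests nothing beyond that limit for bulkier analogues.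

The expectation for compound 4 in this assay is accordingly a step that the limit leaves unreadable from compound 1 to compound 4, most likely again a limit. Compound 4 is estimated at 3000 nM, with a range from 1000 nM to 15000 nM.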

Compound 4, half-maximal effective concentration: > 10000 nM
Compound 4: only a limit was reported; the forecaster's own chance of this, stated with the estimate: 85%; at least 3.3-fold (0.52 log units) between middle value and limit.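

For the compounds shown here, compound 1 and compound 4 are both known only by limits in this assay, and no step between them can be read. The compounds shown leave open where any of them would give an actual number in this assay, and whether replacing chloro with the group in compound 4 shifts cytotoxicity at all.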